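A few compounds are considered here, and "the series" means these few. Any claim that something is new, unique, unknown or untested is made for them only; others in the source may bear on it.

Compound 2 `COc1ccc(CN(C(=O)CSc2nc3ccccc3s2)c2cc(OC)c(OC)c(OC)c2)cc1N`: 491 nM
Compound 3 `COc1ccc(CN(C(=O)CSc2nc3cc(Cl)ccc3s2)c2cc(OC)c(OC)c(OC)c2)cc1O`: 429 nM
Compound 1 `COc1ccc(CN(C(=O)CSc2nc3cc(Br)ccc3s2)c2cc(OC)c(OC)c(OC)c2)cc1O`: 3380 nM

In a functional assay on HCT-116 cells (Homo sapiens) for antiproliferative activity, read by MTT assay, with a stated time of 48 h (a higher number here means a weaker inhibitor, a lower number a stronger inhibitor), compound 2 stands second highest of the three numbers. Compound 3 gives 429 nM, which lies within the scatter of the number for compound 2. Compound 1 gives 3380 nM, which lies beyond that scatter, at a higher number than compound 2. Among the compounds with values here, the one step between measured compounds is a 7.9-fold lower number from compound 1 to compound 3 (0.90 log units; beyond the scatter), and it concerns the halogen on the core rather than the aryl group that changes here.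

Compound 4 `COc1ccc(CN(C(=O)CSc2nc3ccccc3s2)c2cc(OC)c(OC)c(OC)c2)cc1OC` differs from compound 2 in one place: methoxy in place of amino on an aromatic carbon. Within the data shown here, no measured step touches this position, so there is nothing among the measured compounds to fix the size or direction of the change; the hydroxy analogues, compounds 1 and 3, carry different halogens and give no clean comparison. A step of modest size, upward or none beyond the scatter, is therefore expected. Compound 4 is estimated at 1200 nM, with a range of 400 nM to 4000 nM, which is expected to mean a 2.4-fold higher number from compound 2 to compound 4 (0.39 log units; beyond the scatter).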

Compound 4, half-maximal inhibitory concentration: 33900 nM
Beside the measured number, compound 4's estimate is 28-fold (1.45 log units) below it; the whole stated range lies below it.
By their numbers in this assay, from the lowest: compounds 3 and 2 (each within the scatter of the next); then compound 1; then compound 4.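

In this assay, within the data shown here, the change from 3-amino-4-methoxyphenyl to 3,4-dimethoxyphenyl brings a 69-fold higher number from compound 2 to compound 4 (1.84 log units; beyond the scatter), showing that this place on an aromatic carbon, ortho to a methoxy group, is highly sensitive to the group it carries, which no earlier step could show. The swap replaces amino, with 1 heavy atom and 1 hydrogen-bond donor, by methoxy, with 2 heavy atoms and 0 hydrogen-bond donors, and the two compounds cannot separate these differences. Nothing measured here accounts for the size of the step.

As far as these compounds go, whether a dimethylamino or an acetamido group at this place would give a number close to that of compound 2 or of compound 4 remains open. From the compounds shown here alone, compounds 1 and 3 carry hydroxy here but also a halogen on the core, so the effect of hydroxy alone on the unsubstituted core also remains open.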